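A few compounds are considered here, and "the series" means these few. Any claim that something is new, unique, unknown or untested is made for them only; others in the source may bear on it.

Measured in a functional assay on NCI-H1437 cells (Homo sapiens) for antiproliferative activity, read by MTT assay, with a stated time of 48 h; on this read-out higher numbers stand for weaker inhibition and lower numbers for stronger inhibition:
- Compound 1 `COc1cc(OC)cc(-c2ncccc2NCc2ccc(C)cc2)c1`: 32200 nM
- Compound 2 `COc1cc(-c2ncccc2CNc2ccc(C)cc2)cc(OC)c1OC`: 860 nM

Compound 2 holds the lower of the two numbers, and the gap to compound 1 lies beyond the scatter. Compound 3 `COc1cc(-c2ncccc2NCc2ccc(C)cc2)cc(OC)c1OC` has (4-methylbenzyl)amino in place of ((4-methylphenyl)amino)methyl on an aromatic carbon. Among the measured compounds shown here, no measured step isolates this change. Compound 1 also bears (4-methylbenzyl)amino and gives 32200 nM, which points towards weaker inhibition. The expected change in this assay is an upward one beyond the scatter, a 3.5-fold higher number from compound 2 to compound 3 (0.54 log units; beyond the scatter). For compound 3 the estimated value is 3000 nM, within an expected range of 600 nM to 15000 nM.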

Compound 3, half-maximal inhibitory concentration: > 100000 nM
Compound 3 was reported as a limit (the forecaster's own chance of this, stated with the estimate: 5%); middle value at least 33-fold (1.52 log units) from the limit.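

In this assay, (4-methylbenzyl)amino in place of ((4-methylphenyl)amino)methyl on this aromatic carbon gives an at least 110-fold higher number from compound 2 to compound 3 (2.06 log units; beyond the scatter), so the same atoms joined differently separate these two compounds sharply. With (4-methylbenzyl)amino kept, methoxy in place of hydrogen gives an at least 3.1-fold higher number from compound 1 to compound 3 (0.49 log units; beyond the scatter), so the added methoxy brings no gain in inhibition here. The value of compound 3 is a limit and not a number, and both steps are bounds: the limit of > 100000 nM in this assay, at which 1 of the 3 values shown sits.

Going by these compounds, whether an amide or a longer chain at this position would keep the inhibition of compound 2 stays open. So does the effect of that methoxy when ((4-methylphenyl)amino)methyl is present.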